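Acyl replacement on ring nitrogen in a pyrazoline series

The source may report more compounds than this note shows. Statements on the series, on what has been measured and on what is new or still open speak of the compounds shown alone.

Compound 3 `CC(=O)N1N=C(c2ccc(C)cc2)CC1c1cn(-c2ccccc2)nc1-c1ccc(Cl)c(Cl)c1` stands lowest of the three compounds measured in a functional assay on the whole organism (strain Wistar) for inhibition, with Rattus norvegicus as the target, read by paw edema, with a stated time of 30 min, at a dose of 50 mg/kg by the oral route; on this read-out higher numbers stand for more inhibition at the one dose given (going by the name of the read-out) and lower numbers for less inhibition; compound 3 gives 27.7%, and compound 2 `CCC(=O)N1N=C(c2ccc(C)cc2)CC1c1cn(-c2ccccc2)nc1-c1ccc(Cl)c(Cl)c1` gives 29.8%, the two lying within the scatter of each other (a number 2.1 percentage points lower from compound 2 to compound 3 (within the scatter)). Compound 1 `Cc1ccc(C2=NN(c3ccc([N+](=O)[O-])cc3)C(c3cn(-c4ccccc4)nc3-c3ccc(Cl)c(Cl)c3)C2)cc1` gives 57.4%, and both acyl replacements fall clearly below it (a number 27.6 percentage points lower from compound 1 to compound 2 (beyond the scatter); a number 29.7 percentage points lower from compound 1 to compound 3 (beyond the scatter)). Compound 4 `Cc1ccc(C2=NNC(c3cn(-c4ccccc4)nc3-c3ccc(Cl)c(Cl)c3)C2)cc1` differs from compound 3 by hydrogen in place of acetyl on an amine nitrogen in a ring. Among the measured compounds shown here, no measured step removes an acyl group altogether; the measured steps only show that the two acyl groups sit close together and far below the 4-nitrophenyl group. Compound 4 is therefore expected near compound 3, with an estimate of 30% in a range from 15% to 50%. The expected step is a number 2.3 percentage points higher from compound 3 to compound 4 (within the scatter), not reliably beyond the scatter.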

Compound 4, a percentage reported as inhibition, in the whole organism at one dose (the size of the read-out at that dose, not a potency): 38.3%
Compound 4: the middle estimate sits 8.3 percentage points below what was measured, and the stated range covers the measured number.
By their numbers in this assay, from the lowest: compounds 3, 2 and 4 (each within the scatter of the next, the first and the last beyond it); then compound 1.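

Hydrogen in place of acetyl on the ring nitrogen lifts the number (a number 10.6 percentage points higher from compound 3 to compound 4 (beyond the scatter)), so an unsubstituted ring nitrogen is not equivalent to this acyl group, yet hydrogen in place of propanoyl stays inside the usual variation (a number 8.5 percentage points higher from compound 2 to compound 4 (within the scatter)). Hydrogen in place of 4-nitrophenyl still costs clearly (a number 19.1 percentage points lower from compound 1 to compound 4 (beyond the scatter)), which places the unsubstituted nitrogen beneath the aryl substituent. Nothing measured here explains these steps.

Open, from the compounds shown here alone, is whether a plain phenyl or a 4-aminophenyl on this nitrogen keeps the level of compound 1. A benzoyl group or a longer acyl chain is also untested among the compounds shown.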